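From compound 2 to compound 4: starting at a limit

A few compounds are considered here, and "the series" means these few. Any claim that something is new, unique, unknown or untested is made for them only; others in the source may bear on it.

Measured in a functional assay on NCI-H1299 cells (Homo sapiens), read by flow cytometry (a lower number here means that less compound is needed, a higher number that more compound is needed for the effect), and each a limit of the assay:
- compound 1 `N#Cc1ncc2nc1OCC/C=C\COc1ccc(O)cc1NC(=O)N2` gives > 10000 nM
- compound 2 `N#Cc1ncc2nc1OCC/C=C\COc1ccccc1NC(=O)N2` gives > 10000 nM
- compound 3 `CCOc1ccc2c(c1)NC(=O)Nc1cnc(C#N)c(n1)OCCCCCO2` gives > 10000 nM

Compound 2 offers no number to start from. In this assay compound 2 stands at > 10000 nM as a limit, not a number, and the two further values shown are limits too. Among the measured compounds shown here, the whole series so far comes down to the limit of > 10000 nM in this assay, at which 3 of the 3 values shown sit, and not one measured number.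

Compound 4 `N#Cc1ncc2nc1OCC/C=C\COc1ccc(CCOC3CCCCO3)cc1NC(=O)N2` keeps the core of compound 2 and differs from it in one place: 2-((oxan-2-yl)oxy)ethyl in place of hydrogen on an aromatic carbon. The new group, 2-((oxan-2-yl)oxy)ethyl, brings one six-membered non-aromatic ring onto the aromatic ring of carbon only.

For the measured compounds named here, only one measured step bears on this change. That step, hydrogen in place of hydroxy on an aromatic carbon, is a step that the two limits leave unreadable from compound 1 to compound 2 and so gives no size to carry over. With compound 2 at > 10000 nM as a limit, no move beyond the scatter is expected in either direction. The expected step is a number no higher from compound 2 to compound 4 (the limit leaves the size open) and it is only an estimate.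

For compound 4 the estimated value is 10000 nM with an expected range from 3000 nM to 30000 nM, and the assay may well report only a limit again.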

Compound 4, half-maximal effective concentration: > 10000 nM
Compound 4: a limit, no number; the forecaster's own chance of this, stated with the estimate: 75%; the middle value sits exactly at the limit.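

In this assay compound 4 gives > 10000 nM, which is a limit and not a number. The steps to compound 4 from compound 2 and from compound 1 cannot be read, since all three values are limits. The compounds shown leave open how much of any of them the effect needs, and whether 2-((oxan-2-yl)oxy)ethyl changes that amount at all. The series comes down to one value: the limit of > 10000 nM in this assay, at which 4 of the 4 values shown sit.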